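The source may hold more compounds than are shown below. What is called first, only, known or untested is meant among the compounds shown, and "the series" means these compounds.

Measured so far:
compound 1 `CN/C(=N/C#N)NCCCCc1nc[nH]c1C` — < 5
compound 2 `Cc1[nH]cnc1CCCCN/C(=N\C#N)NCCSc1ccccc1` — 5.36

Compound 1 in a functional assay on Sf9 cells for antagonist activity at histamine H2 receptor (Homo sapiens), read by scintillation counting and GTPgammaS binding, with a stated time of 90 min (a higher number here means a more potent compound, by a factor of ten per unit of this negative logarithm, a lower number a less potent compound), gives only a limit of the assay, < 5. Going by the values given here, compound 2 in this assay gives 5.36, the only number. The other value shown, that of compound 1, is a limit (the limit of < 5 in this assay, at which 1 of the 2 values shown sits). Among the compounds with values here, the single measured step, a number at least 0.36 log units higher from compound 1 to compound 2 (beyond the scatter), follows the addition of (phenylsulfanyl)methyl on a saturated chain carbon bound to an amine nitrogen, and its size is known only as a lower bound.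

Compound 3 `N#C/N=C(\NCCNc1ccnc(N)n1)NCCSc1ccccc1` differs from compound 2 by (2-aminopyrimidin-4-yl)amino in place of 2-(5-methyl-1H-imidazol-4-yl)ethyl on a saturated chain carbon, two bonds along the chain from an amine nitrogen. Within the data shown here, this change sits at the other end of the chain from the place altered in the measured step, so a number at least 0.36 log units higher from compound 1 to compound 2 (beyond the scatter) does not bear on it directly; no measured pair shows what exchanging the five-membered ring end for the six-membered ring end does. With nothing in the series pointing to a direction, compound 3 is expected to sit close to compound 2, with a wide range to cover the unknown effect. The expected step is a number 0.04 log units higher from compound 2 to compound 3 (within the scatter). Compound 3 is thus estimated at 5.4, with a range from 4.5 to 6.4.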

Compound 3, negative logarithm of the antagonist equilibrium constant: < 5
Compound 3 ended at the assay's limit (the forecaster's own chance of this, stated with the estimate: 30%); middle value at least 0.40 log units away from the limit.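

The end of the chain carrying the ring now has a measured step of its own: with (2-aminopyrimidin-4-yl)amino in place of 2-(5-methyl-1H-imidazol-4-yl)ethyl, this assay shows a number at least 0.36 log units lower from compound 2 to compound 3 (beyond the scatter). The phenylsulfanyl end is shared by compound 2 and compound 3, so it does not by itself keep a compound clear of the assay's limit, and the group at this place on the saturated chain carbon matters as well. The size of this step is known only as a lower bound, the value of compound 3 being a limit of the assay: the limit of < 5 in this assay, at which 2 of the 3 values shown sit.

Which feature of the exchanged end counts stays open, since this one pair changes the ring size, the make-up of the ring atoms and the numbers of hydrogen-bond donors and acceptors all together. Whether a plain primary amine at this place, or a longer chain leading to the 5-methyl-1H-imidazol-4-yl ring, would hold or raise the value seen for compound 2 cannot be told from these compounds.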